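The source may hold more compounds than are shown below. What is called first, only, known or untested is meant among the compounds shown, and "the series" means these compounds.

Values in a functional assay on HGC-27 cells (Homo sapiens) for antiproliferative activity, read by MTT assay, with stated times of 72 h and 4 h; on this read-out higher numbers stand for weaker inhibition and lower numbers for stronger inhibition:
- compound 1 `COc1ncc(-c2cc3c(N4C[C@@H](C)O[C@@H](C)C4)ncnc3s2)cc1NS(=O)(=O)c1ccc(F)cc1F`: 560 nM
- compound 2 `COc1ncc(-c2cc3c(N4CC(C)OC(C)C4)ncnc3s2)cc1NS(=O)(=O)c1ccc(F)cc1F`: 860 nM
- compound 3 `COc1ncc(-c2cc3c(N4CC5CCCC5C4)ncnc3s2)cc1NS(=O)(=O)c1ccc(F)cc1F`: 1900 nM

Compound 3 has the highest number of the three, and both of its steps lie beyond the scatter: a 3.4-fold higher number from compound 1 to compound 3 (0.53 log units; beyond the scatter) and a 2.2-fold higher number from compound 2 to compound 3 (0.34 log units; beyond the scatter). Both are modest. The remaining step, a 1.5-fold higher number from compound 1 to compound 2 (0.19 log units; within the scatter), stays within the scatter; the only difference there is the fact that one of compounds 1 and 2 is drawn with a defined configuration and the other without, at the place where they differ. Those two compounds therefore count as one reference level.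

Still unmeasured is compound 4 `COc1ncc(-c2cc3c(N4CCN(C)CC4)ncnc3s2)cc1NS(=O)(=O)c1ccc(F)cc1F`. The change from compound 3 is a group of 7 heavy atoms (5 carbon, 2 nitrogen; one six-membered non-aromatic ring with 2 hetero atoms) in place of a group of 8 heavy atoms (7 carbon, 1 nitrogen; one five-membered non-aromatic ring of carbon only, one five-membered non-aromatic ring with 1 hetero atom), on an aromatic carbon: the fused group leaves and 4-methylpiperazin-1-yl enters, on the same aromatic carbon of the shared core. Compound 4 thus again carries a six-membered non-aromatic ring with 2 hetero atoms, as compound 1 and compound 2 do, although the group is not the same.

Among the compounds with values here, the two steps into compound 3 are the only measured exchanges at this place. Read in reverse, they suggest a modest move to a lower number in this assay, but the new group has no measured precedent, so a result within the scatter of compound 3 remains possible. The expected change is a 1.9-fold lower number from compound 3 to compound 4 (0.28 log units; within the scatter). For compound 4 the estimated value is 1000 nM, with an expected range of 350 nM to 2800 nM.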

Compound 4, half-maximal inhibitory concentration: 560 nM
For compound 4 the middle estimate is 1.8-fold (0.25 log units) above the measured one; the measured number falls inside the stated range.
By their numbers in this assay, from the lowest: compounds 1, 4 and 2 (each within the scatter of the next); then compound 3.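

In this assay, 4-methylpiperazin-1-yl shows that a six-membered non-aromatic ring with 2 hetero atoms at this position need not contain the ring oxygen of 2,6-dimethylmorpholin-4-yl: a 1.5-fold lower number from compound 2 to compound 4 (0.19 log units; within the scatter) and no change at the digits printed from compound 1 to compound 4 (within the scatter) place it level with both compounds that carry that group. The fused group of compound 3 now stands alone among the groups shown, with a 3.4-fold lower number from compound 3 to compound 4 (0.53 log units; beyond the scatter), so the higher number of compound 3 goes with that one group and not with any departure from 2,6-dimethylmorpholin-4-yl. Nothing measured here gives a reason for the difference between the fused group and the two six-membered groups.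

Open, from the compounds shown here alone, is whether the level of compound 4 depends on the methyl group on the piperazine nitrogen, which unsubstituted piperazin-1-yl or 4-acetylpiperazin-1-yl would address. Also open, going by these compounds, is whether a second hetero atom in the ring is needed at all, a question for piperidin-1-yl, and whether an open-chain amine such as dimethylamino can take the place of a ring at this position.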